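Larger amide cap on the fused lactam series

A few compounds are considered here, and "the series" means these few. Any claim that something is new, unique, unknown or untested is made for them only; others in the source may bear on it.

Compound 3 `CC1CC1C(=O)N1CCc2nc(C#Cc3ccccc3)sc2C1` carries a 2-methylcyclopropyl amide on the ring nitrogen of the shared core. In an assay on HEK293 cells for negative allosteric modulation of metabotropic glutamate receptor 5 (Homo sapiens), read by FLIPR, with a stated time of 1 h (a lower number here means a stronger inhibitor, a higher number a weaker inhibitor), compound 3 gives > 10000 nM, which is a limit of the assay and not a number. Compound 1 `O=C1NCCc2nc(C#Cc3cccc(F)c3)sc21` gives > 10000 nM in this assay, again a limit. Compound 2 `Cc1cccc(C#Cc2nc3c(s2)C(=O)NCC3)c1` gives > 10000 nM in this assay, also a limit. Among the compounds with values here, the one single-point step on record, a step that the two limits leave unreadable from compound 1 to compound 2, stays unreadable because of the limit of > 10000 nM in this assay, at which 3 of the 3 values shown sit. Compound 4 `CC1CCCC(C(=O)N2CCc3nc(C#Cc4ccccc4)sc3C2)C1` differs from compound 3 by 3-methylcyclohexyl in place of 2-methylcyclopropyl on a carbonyl carbon. Within the data shown here, no measured step changes the amide substituent, so nothing here speaks for or against this particular swap; the only guidance is that every value so far sits at the limit. The expected step is therefore a number no higher from compound 3 to compound 4 (the limit leaves the size open), which amounts to no change that could be read against the limit. For compound 4 the estimate in this assay is 10000 nM, with a range from 2000 nM to 30000 nM, and a limit rather than a number is the more likely outcome.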

Compound 4, half-maximal inhibitory concentration: > 10000 nM
Compound 4: a limit, no number; the forecaster's own chance of this, stated with the estimate: 70%; the middle value lies on the limit itself.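

Compound 3 and compound 4 both stand at a limit and not at a number, so no step between them can be read, because every result shown sits there: the limit of > 10000 nM in this assay, at which 4 of the 4 values shown sit.

The compounds shown leave open whether 3-methylcyclohexyl and 2-methylcyclopropyl differ at all in this assay.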